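Turning the Stereocentre of Compound 3

The source may report more compounds than this note shows. Statements on the series, on what has been measured and on what is new or still open speak of the compounds shown alone.

Compound 3 `CC(C)[C@@H](N)C(=O)Nc1cc2cc[nH]c(=O)c2cc1Cl` is one of three amino-acid amides on a shared core examined in an assay on isolated protein for inhibition of Rho-associated protein kinase 2 (Homo sapiens); on this read-out lower numbers stand for stronger inhibition and higher numbers for weaker inhibition. Compound 1 `N[C@H](C(=O)Nc1cc2cc[nH]c(=O)c2cc1Cl)C1CCCCC1` gives 20 nM, compound 2 `CC(C)C[C@H](N)C(=O)Nc1cc2cc[nH]c(=O)c2cc1Cl` gives 340 nM, and compound 3 gives 240 nM, which leaves compound 3 with the second highest of the three numbers, a step from compound 3 within the scatter of compound 2 and well apart from compound 1.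

Among the compounds with values here, compound 4 `CC(C)[C@H](N)C(=O)Nc1cc2cc[nH]c(=O)c2cc1Cl` keeps every atom and bond of compound 3; the only change is the two compounds have the same atoms and bonds and differ only in configuration as drawn: 1 of 1 stereo elements differ; a stereocentre at a saturated chain carbon is drawn R in compound 3 and S in compound 4. Within the data shown here, the two measured steps, a 17-fold higher number from compound 1 to compound 2 (1.23 log units; beyond the scatter) and a 1.4-fold lower number from compound 2 to compound 3 (0.15 log units; within the scatter), both alter the side chain on the saturated chain carbon and say nothing about configuration, so there is no direct precedent here. Since compounds 1, 2 and 3 all share one drawn configuration, the expectation is that drawing the stereocentre the other way gives a weaker inhibitor, and compound 4 is estimated at 1200 nM (range 150 nM to 8000 nM), an expected step of a 5.0-fold higher number from compound 3 to compound 4 (0.70 log units; beyond the scatter), held with low confidence.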

Compound 4, half-maximal inhibitory concentration: 12 nM
Compound 4: middle estimate off by 100-fold (2.00 log units), on the high side; measured number below the stated range.
By their numbers in this assay, from the lowest: compounds 4 and 1 (each within the scatter of the next); then compounds 3 and 2 (each within the scatter of the next).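

The configuration at the saturated chain carbon has a large effect in its own right (a 20-fold lower number from compound 3 to compound 4 (1.30 log units; beyond the scatter)), and that step can be assigned to this stereocentre alone because nothing else separates the pair: the fact that compounds 3 and 4 differ only in the configuration as drawn. With the stereocentre drawn as in compound 4, the side chain also matters, though not in step with its size: isopropyl lies far from isobutyl (a 28-fold lower number from compound 2 to compound 4 (1.45 log units; beyond the scatter)) yet stays within the scatter of cyclohexyl (a 1.7-fold lower number from compound 1 to compound 4 (0.22 log units; within the scatter)). The small gap between compound 2 and compound 3 therefore cannot be read as a side-chain comparison alone, since those two compounds also differ in their drawn configuration.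

From the compounds shown here alone, whether turning the stereocentre matters as much in compound 1 and compound 2 stays open. So does how a tert-butyl or phenyl group on this carbon would compare with isopropyl and cyclohexyl.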